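The source may report more compounds than this note shows. Statements on the series, on what has been measured and on what is new or still open speak of the compounds shown alone.

In an ADME assay on HepG2 cells (Homo sapiens) for cytotoxicity, read by MTT assay (on this read-out higher numbers stand for weaker inhibition and lower numbers for stronger inhibition), compound 1 (`O=C(Nc1ccccc1)Oc1ccc(Cl)cc1C(=O)Nc1ccc(Cl)cc1`) gives > 250000 nM, which is a limit and not a number. Compound 2 (`O=C(NC1CCCCC1)Oc1ccc(Cl)cc1C(=O)Nc1ccc(Cl)cc1`) gives > 250000 nM, also a limit. Going by the values given here, the series so far therefore stands at the limit of > 250000 nM in this assay, at which 2 of the 2 values shown sit. Among the compounds with values here, the only measured step is a step that the two limits leave unreadable from compound 1 to compound 2, so no measured size carries over to the next change. Compound 3 (`O=C(Nc1ccccc1)Oc1ccc(Cl)cc1C(=O)Nc1ccc(C(F)(F)F)cc1`) differs from compound 1 by trifluoromethyl in place of chloro on an aromatic carbon, with trifluoromethyl in place of chloro on an aromatic carbon, para to a large group. No change beyond the scatter is expected, and the estimated step is an at least 1.1-fold lower number from compound 1 to compound 3 (0.05 log units; that floor lies within the scatter). Compound 3 is estimated at 220000 nM, with an expected range of 80000 nM to 400000 nM.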

Compound 3, half-maximal inhibitory concentration: 9800 nM
Estimate against measurement, compound 3: 22-fold (1.35 log units) above, and the stated range ends above it.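

In this assay, trifluoromethyl in place of chloro on an aromatic carbon, para to a large group, gives an at least 25-fold lower number from compound 1 to compound 3 (1.40 log units; beyond the scatter), so this position can carry the read-out clear of the limit. Compound 1 gives > 250000 nM, which is a limit, so the step has a floor and no exact size. Compound 3 alone now stands off that limit: the limit of > 250000 nM in this assay, at which 2 of the 3 values shown sit.

Going by these compounds, whether a nitrile or a methyl group at this position would give a similar step stays open. Also open, on these data alone, is how cyclohexyl on the amide-type nitrogen would read alongside trifluoromethyl.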